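This account rests on a few compounds, and the source may have more. Where it says the series, first, only, none or still open, it means among the compounds named here.

Compound 2 `CC(C)=CCc1cc(C(=O)Nc2cc3ccc(OCCCN4CCCCC4)c(C)c3oc2=O)ccc1O` stands in a functional assay on SK-BR-3 cells (Homo sapiens) for antiproliferative activity (on this read-out higher numbers stand for weaker inhibition and lower numbers for stronger inhibition), only as a limit, > 50000 nM, which is the limit of > 50000 nM in this assay, at which 1 of the 3 values shown sits. Its two neighbours carry numbers: compound 1 `CC(C)=CCc1cc(C(=O)Nc2cc3ccc(OCC4CCCNC4)c(C)c3oc2=O)ccc1O` gives 600 nM in this assay, and compound 3 `CCCNCCCOc1ccc2cc(NC(=O)c3ccc(O)c(CC=C(C)C)c3)c(=O)oc2c1C` gives 990 nM in this assay. Compound 4 `CC(C)=CCc1cc(C(=O)Nc2cc3ccc(OCCCNCc4ccccc4)c(C)c3oc2=O)ccc1O` differs from compound 2 in one place: benzylamino in place of piperidin-1-yl on a saturated chain carbon, three bonds along the chain from an oxygen on an aromatic ring. The step that bears on it most closely is the one in which the piperidin-1-yl was likewise replaced, an at least 50-fold lower number from compound 2 to compound 3 (1.70 log units; beyond the scatter). The step of an at least 83-fold higher number from compound 1 to compound 2 (1.92 log units; beyond the scatter) shows the same piperidin-1-yl from the other side. A step of a similar size, in the same direction, is therefore expected for compound 4, an at least 33-fold lower number from compound 2 to compound 4 (1.52 log units; beyond the scatter). Compound 4 is estimated at 1500 nM in this assay, with a range from 400 nM to 10000 nM.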

Compound 4, half-maximal inhibitory concentration: 470 nM
Compound 4: the middle estimate sits 3.2-fold (0.50 log units) above what was measured, within the range that was stated.
By their numbers in this assay, from the lowest: compounds 4, 1 and 3 (each within the scatter of the next, the first and the last beyond it). At a limit, above all of these: compound 2.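

Compound 2 is known only as a limit of the assay: the limit of > 50000 nM in this assay, at which 1 of the 4 values shown sits. Against that limit, benzylamino gives an at least 100-fold lower number from compound 2 to compound 4 (2.02 log units; beyond the scatter), so an aromatic ring of carbon only is tolerated at the end of this chain when it sits on a secondary amine. The same group also gives a 2.1-fold lower number from compound 3 to compound 4 (0.32 log units; beyond the scatter), a modest step beyond propylamino, while a 1.3-fold lower number from compound 1 to compound 4 (0.11 log units; within the scatter) sets no order against the piperidin-3-yl side chain. On these data alone, whether the change from compound 2 depends on the hydrogen-bond donor or on the aromatic ring stays open. So does what a cyclohexylmethylamino or a 2-phenylethylamino group would give at this place.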